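Removing one chloro from compound 3

A few compounds are considered here, and "the series" means these few. Any claim that something is new, unique, unknown or untested is made for them only; others in the source may bear on it.

In a functional assay on MDA-MB-231 cells (Homo sapiens) for cytotoxicity, read by MTT assay, with a stated time of 72 h (on this read-out higher numbers stand for weaker inhibition and lower numbers for stronger inhibition), compound 3 (`CC1CCN(Cc2ccc3nc(NC(=O)N/N=C/c4cn(Cc5ccccc5Cl)c5ccccc45)sc3c2)CC1`) gives 1360 nM. Compound 1 (`CC1CCN(Cc2ccc3nc(NC(=O)N/N=C/c4cn(Cc5cccc(Cl)c5)c5ccccc45)sc3c2)CC1`) gives 2110 nM, and compound 2 (`CC1CCN(Cc2ccc3nc(NC(=O)N/N=C/c4c[nH]c5ccccc45)sc3c2)CC1`) gives 2460 nM, so all three lie within the usual scatter of one another. Compound 4 (`CC1CCN(Cc2ccc3nc(NC(=O)N/N=C/c4cn(Cc5ccccc5)c5ccccc45)sc3c2)CC1`) differs from compound 3 by one change: hydrogen in place of chloro on an aromatic carbon. The nearest evidence is modest. Swapping 3-chlorophenyl for 2-chlorophenyl gave a 1.6-fold lower number from compound 1 to compound 3 (0.19 log units; within the scatter), and placing 2-chlorobenzyl where hydrogen stood on an aromatic nitrogen gave a 1.8-fold lower number from compound 2 to compound 3 (0.26 log units; within the scatter). Replacing 3-chlorobenzyl with hydrogen gave a 1.2-fold higher number from compound 1 to compound 2 (0.07 log units; within the scatter). All stayed within the scatter, so no clear shift is expected in this assay. The expected step is a 1.3-fold higher number from compound 3 to compound 4 (0.12 log units; within the scatter). The estimated value for compound 4 is 1800 nM, within a range of 900 nM to 3500 nM.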

Compound 4, half-maximal inhibitory concentration: 2850 nM
Estimate against measurement, compound 4: 1.6-fold (0.20 log units) below; the measured number falls inside the stated range.
By their numbers in this assay, from the lowest: compounds 3, 1, 2 and 4 (each within the scatter of the next, the first and the last beyond it).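

In this assay, within the data shown here, taking the chloro off the 2-chlorobenzyl group gives the only single change here that passes the scatter (a 2.1-fold higher number from compound 3 to compound 4 (0.32 log units; beyond the scatter)), while taking it off the 3-chlorobenzyl group stays within it (a 1.4-fold higher number from compound 1 to compound 4 (0.13 log units; within the scatter)). Benzyl in place of hydrogen on the aromatic nitrogen also stays within the scatter (a 1.2-fold higher number from compound 2 to compound 4 (0.06 log units; within the scatter)), so the plain benzyl group shows no effect of its own. Nothing measured here accounts for the difference between the two chloro positions.

Going by these compounds, whether this step belongs to chlorine in particular remains open, since fluoro, bromo or methyl at the same place could give a similar number. A 4-chlorobenzyl group would also show how the third chloro position compares.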